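Swapping piperidin-1-yl for 3-oxomorpholin-4-yl at the assay limit

A few compounds are considered here, and "the series" means these few. Any claim that something is new, unique, unknown or untested is made for them only; others in the source may bear on it.

- Compound 1 `NC(=O)c1sccc1OCCc1ccccc1` gives > 100000 nM (a limit)
- Compound 2 `NC(=O)c1sc(N2CCCCC2)cc1OCCc1ccccc1` gives > 100000 nM (a limit)

In an ADME assay on Vero cells (Chlorocebus sabaeus) for inhibition, read by CellTiter-Glo, with a stated time of 2 days (on this read-out lower numbers stand for stronger inhibition and higher numbers for weaker inhibition), compound 2 gives > 100000 nM as a limit of the assay, not a number. Compound 3 `NC(=O)c1sc(N2CCOCC2=O)cc1OCCc1ccccc1` is the next to be read. It carries 3-oxomorpholin-4-yl in place of piperidin-1-yl on an aromatic carbon, next to the ring sulfur (counted in full: 3-oxomorpholin-4-yl in place of piperidin-1-yl on an aromatic carbon). Within the data shown here, the only measured step that bears on this is a step that the two limits leave unreadable from compound 1 to compound 2 (it concerns the same aromatic carbon), and it offers no size to carry over. The other guide is the limit of > 100000 nM in this assay, at which 2 of the 2 values shown sit (no measured number exists yet). No step beyond the scatter is therefore expected in this assay in either direction, and another limit is the likeliest result. The expected outcome is a number no higher from compound 2 to compound 3 (the limit leaves the size open) as an estimate only. Compound 3 is estimated at 100000 nM with an expected range from 40000 nM to 250000 nM in this measurement.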

Compound 3, half-maximal inhibitory concentration: > 100000 nM
Compound 3 was reported as a limit; the forecaster's own chance of this, stated with the estimate: 85%; the middle value lies on the limit itself.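

In this assay no step can be read among compound 1, compound 2 and compound 3, since each is reported only as a limit: the limit of > 100000 nM in this assay, at which 3 of the 3 values shown sit.

The compounds shown leave open how strongly any of them inhibits, and whether piperidin-1-yl and 3-oxomorpholin-4-yl differ at all on this read-out.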